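Removing the (2-Methoxyethyl)amino Group from a Small Fused Core

This account rests on a few compounds, and the source may have more. Where it says the series, first, only, none or still open, it means among the compounds named here.

Measured compounds:
- compound 1, `COCCNc1nc(C)cc2c1c(N)nn2C`: 5%
- compound 2, `COCCNc1nc(-c2ccccc2)cc2c1c(N)nn2C`: 1%
- compound 3, `Cn1nc(N)c2cnc(-c3ccccc3)cc21`: 5%

All three compounds were tested in an assay on isolated protein for inhibition of MAP kinase-activated protein kinase 5 (Homo sapiens), read by mobility shift assay, tested at 30 uM (on this read-out lower numbers stand for less inhibition and higher numbers for more inhibition at the one concentration tested (going by the name of the read-out)), and all three gave low numbers. Compound 1 and compound 3 are level at the digits given, and the step from compound 1 to compound 2 is a number 4 percentage points lower from compound 1 to compound 2 (within the scatter). The two cores differ by methyl in place of phenyl on an aromatic carbon. The change from compound 2 to compound 3 is hydrogen in place of (2-methoxyethyl)amino on an aromatic carbon, and that step was a number 4 percentage points higher from compound 2 to compound 3 (within the scatter).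

Compound 4, `Cc1cc2c(cn1)c(N)nn2C`, has not yet been measured. It differs from compound 1 by hydrogen in place of (2-methoxyethyl)amino on an aromatic carbon. Among the measured compounds shown here, this is the same kind of change as the one from compound 2 to compound 3, but the surroundings are not identical: in compound 2 the position is meta to a phenyl group, whereas in compound 1 it is meta to a methyl group. Because the earlier step was a number 4 percentage points higher from compound 2 to compound 3 (within the scatter), and because compound 3 itself gives 5%, the step from compound 1 to compound 4 is expected to be no change at the digits printed from compound 1 to compound 4 (within the scatter), which rests on the three measured compounds all sitting at low readings regardless of the substituent pattern. For compound 4 the expected reading is 5%, most likely between 0% and 15%.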

Compound 4, a percentage reported as inhibition, at one concentration (the size of the read-out at that concentration, not a potency): 9%
Compound 4: middle estimate off by 4 percentage points, on the low side; low and high end bracket the measured number.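

Hydrogen in place of (2-methoxyethyl)amino on an aromatic carbon gave a number 4 percentage points higher from compound 1 to compound 4 (within the scatter) in this assay. Set beside the earlier case, where the same change was made on the core carrying phenyl rather than methyl, the two steps do not differ: the same change on two cores in this assay, a number 4 percentage points higher (within the scatter) from compound 2 to compound 3 and a number 4 percentage points higher (within the scatter) from compound 1 to compound 4, 0 percentage points apart, within the scatter of two such steps This shows that, across these two cores, the change carried over without any step beyond the scatter, but it does not show that the change has a real effect on inhibition, since neither step can be told apart from repeated-measurement noise and all four compounds stay at low readings at the one concentration tested.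

The compounds shown leave open whether the same agreement between cores would hold in a compound with a clearly higher reading, where a step could stand out from the scatter, and whether any other group on that aromatic carbon, such as a morpholine ring, a carboxylic acid or a longer amine chain, would move the reading at all. They also leave open whether a group other than methyl or phenyl on the second aromatic carbon, such as a pyridine ring, would lift these compounds from the low readings seen so far.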